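Swapping the halogenated phenyl ring: fluorine for chlorine

The compounds below may be only part of what the source reports. "The series", "measured", "known", "first", "only" and "open" are said of these compounds alone.

compound 1 `CN(CC1=CC[C@H]2C[C@@H]1C2(C)C)Cc1ccc(-c2cccc(F)c2)cc1`: 2510 nM
compound 2 `COC(=O)c1cccc(-c2ccc(CN(C)CC3=CC[C@H]4C[C@@H]3C4(C)C)cc2)c1`: a limit, > 316 nM
compound 3 `CN(CC1=CC[C@H]2C[C@@H]1C2(C)C)Cc1ccc(-c2ccc(Cl)cc2)cc1`: not yet measured

In an assay on HEK293 cells for displacement of a labelled ligand from C-X-C chemokine receptor type 3 (Homo sapiens) (on this read-out higher numbers stand for weaker inhibition and lower numbers for stronger inhibition), compound 1 gives the only number shown, 2510 nM. Compound 2 reached only a limit of the assay, > 316 nM. The step that the limit leaves unreadable from compound 1 to compound 2 therefore cannot be read, as the limit of > 316 nM in this assay, at which 1 of the 2 values shown sits, shows. Compound 3 differs from compound 1 by 4-chlorophenyl in place of 3-fluorophenyl on an aromatic carbon. Among the compounds with values here, no measured step speaks to this change, so the expected step of a 1.3-fold lower number from compound 1 to compound 3 (0.10 log units; within the scatter) is one within the usual scatter, in no clear direction. Compound 3 is thus estimated at 2000 nM, with a range from 600 nM to 7000 nM.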

Compound 3, inhibition constant: > 316 nM
Compound 3 ended at the assay's limit; the forecaster's own chance of this, stated with the estimate: 25%; the middle value does not contradict the limit.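

In this assay compound 3 gives > 316 nM as a limit of the assay and not a number. The step from compound 1 to compound 3 therefore cannot be read: the limit of > 316 nM in this assay, at which 2 of the 3 values shown sit. The compounds shown leave open how far either change, in compound 2 or compound 3, moves the number from that of compound 1.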